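The compounds below may be only part of what the source reports. "The series", "measured", "known", "first", "only" and "open" are said of these compounds alone.

Measured compounds:
compound 1, `O=C(CSc1nc(Nc2ccccc2)c2ccccc2n1)Nc1ccccc1Cl`: 24400 nM
compound 2, `O=C(CSc1nc(Nc2ccccc2)c2ccccc2n1)Nc1ccccc1Br`: 14100 nM
compound 3, `O=C(CSc1nc(Nc2ccccc2)c2ccccc2n1)Nc1ccc(Cl)cc1`: 17200 nM

These three values come from a functional assay on MDA-MB-231 cells (Homo sapiens) for inhibition, read by MTT assay, with a stated time of 72 h; on this read-out lower numbers stand for stronger inhibition and higher numbers for weaker inhibition. Compound 1 and compound 3 share the same atoms joined differently: 4-chlorophenyl in place of 2-chlorophenyl on an amide-type nitrogen describes how their cores differ, and in this assay the step is a 1.4-fold lower number from compound 1 to compound 3 (0.15 log units; within the scatter). Compound 2 differs from compound 1 by bromo in place of chloro on an aromatic carbon, and that change gave a 1.7-fold lower number from compound 1 to compound 2 (0.24 log units; within the scatter). Compound 4, `O=C(CSc1nc(Nc2ccccc2)c2ccccc2n1)Nc1ccc(Br)cc1`, is not yet measured; it differs from compound 3 by bromo in place of chloro on an aromatic carbon. Among the measured compounds shown here, this is the same kind of change as the one from compound 1 to compound 2, but the place is not identical: in compound 1 the changed carbon is ortho to a large group, while in compound 3 it is para to a large group. The account therefore rests on a single earlier instance. For the measured compounds named here, compound 4 is expected to show a 1.5-fold lower number from compound 3 to compound 4 (0.17 log units; within the scatter) in this assay, a step sized after a 1.7-fold lower number from compound 1 to compound 2 (0.24 log units; within the scatter), which is the only measured example of this change. On that basis compound 4 is estimated at 11500 nM in this assay. Compound 4 is expected to fall between 6000 nM and 24000 nM in this assay.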

Compound 4, half-maximal inhibitory concentration: 11500 nM
For compound 4 middle estimate and measured number coincide at the digits printed; the measured number falls inside the stated range.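

In this assay, bromo in place of chloro, para to a large group, gave a 1.5-fold lower number from compound 3 to compound 4 (0.17 log units; within the scatter), and this step agrees with the earlier one: the same change on two cores in this assay, a 1.7-fold lower number (0.24 log units; within the scatter) from compound 1 to compound 2 and a 1.5-fold lower number (0.17 log units; within the scatter) from compound 3 to compound 4, 1.2-fold (0.06 log units) apart, within the scatter of two such steps. The change therefore carried from one core to the other at a similar size, but each step on its own lies within the scatter, and two instances do not show that bromo reliably lowers the number across the series. Among the compounds shown here, the shift from 2-bromophenyl to 4-bromophenyl gave a 1.2-fold lower number from compound 2 to compound 4 (0.09 log units; within the scatter), while the step combining a new halogen with a new place on the ring gave a 2.1-fold lower number from compound 1 to compound 4 (0.33 log units; beyond the scatter), the only one of the new steps to pass beyond the scatter, and then only modestly.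

The compounds shown leave open what a fluoro, a methoxy or a carboxylic acid would do on the same phenyl ring. They also leave open what would follow if a morpholine or another amine took the place of the unchanged phenylamino group.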